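Chloro in place of methyl: expectation for compound 4

The compounds below may be only part of what the source reports. "The series", "measured", "known", "first", "only" and "open" are said of these compounds alone.

Compound 2 `Cc1ccc(-c2csc(N/N=C/c3ccc(Cl)cc3Cl)n2)cc1` gives 76.2% in a functional assay, read by spectrophotometry, with a stated time of 15 min, tested at 20 ug/mL (a higher number here means a stronger effect of the compound at the concentration tested, a lower number a weaker effect), the second highest of three numbers, though within the scatter of compound 1. Compound 1 `COC(=O)c1cc(-c2csc(N/N=C/c3cccs3)n2)ccc1OCc1ccccc1` gives 79.6% in this assay. Compound 3 `COC(=O)c1cc(-c2csc(N/N=C/c3ccc(Cl)cc3Cl)n2)ccc1OCc1ccccc1` gives 58.9% in this assay, beyond the scatter below compound 2. Compound 4 `Clc1ccc(-c2csc(N/N=C/c3ccc(Cl)cc3Cl)n2)cc1` differs from compound 2 by chloro in place of methyl on an aromatic carbon. Among the compounds with values here, the single measured step, a number 20.7 percentage points lower from compound 1 to compound 3 (beyond the scatter), concerns the group on a carbon with a double bond to nitrogen, not the six-membered aromatic ring of carbon only, so no measured step bears directly on this change. The step from compound 2 to compound 4 is therefore expected as a number 2.2 percentage points lower from compound 2 to compound 4 (within the scatter), none beyond the scatter. Compound 4 is estimated at 74%, range 55% to 88%.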

Compound 4, a percentage reported as inhibition, at one concentration (the size of the read-out at that concentration, not a potency): 76%
Estimate against measurement, compound 4: 2 percentage points below, and the stated range covers the measured number.
By their numbers in this assay, from the lowest: compound 3; then compounds 4, 2 and 1 (each within the scatter of the next).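

In this assay, within the data shown here, the change from 4-methylphenyl to 4-chlorophenyl gives a number 0.2 percentage points lower from compound 2 to compound 4 (within the scatter) and is the first step read at this position, as the only earlier step concerned the group on the carbon with a double bond to nitrogen. With 2,4-dichlorophenyl held fixed on that carbon, methyl and chloro are not told apart here. No available measurement gives a reason for this result.

As far as these compounds go, whether this position accepts an amine, a carboxylic acid or a longer chain in place of chloro remains open. From the compounds shown here alone, whether chloro in place of methyl reads the same with thiophen-2-yl on that carbon also remains open.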